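Adding a Second Trifluoromethyl to the Urea Phenyl Ring

A few compounds are considered here, and "the series" means these few. Any claim that something is new, unique, unknown or untested is made for them only; others in the source may bear on it.

Three urea compounds sharing one core have been tested in a functional assay on U-251 cells (Homo sapiens) for inhibition, read by sulforhodamine B assay, with a stated time of 48 h, tested at 10 uM; a lower number here means a stronger effect, a higher number a weaker effect of the compound at the concentration tested. Compound 1 `COc1cc(Cl)cc(-c2nn(-c3cccc(NC(=O)Nc4cccc(C(F)(F)F)c4)c3)cc2-c2ccncc2)c1` gives 4.59%, the highest number among the three. Compound 3 `COc1cc(Cl)cc(-c2nn(-c3cccc(NC(=O)Nc4ccc(Cl)c(Cl)c4)c3)cc2-c2ccncc2)c1` gives 3.01%, and the change a number 1.6 percentage points lower from compound 1 to compound 3 (within the scatter) is within the scatter. Compound 2 `COc1cc(Cl)cc(-c2nn(-c3cccc(NC(=O)Nc4ccc(Cl)c(C(F)(F)F)c4)c3)cc2-c2ccncc2)c1` gives -48.3%, and the change a number 52.9 percentage points lower from compound 1 to compound 2 (beyond the scatter) stands out. The reverse comparison, a number 51.3 percentage points higher from compound 2 to compound 3 (beyond the scatter), also stands out.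

Compound 4 `COc1cc(Cl)cc(-c2nn(-c3cccc(NC(=O)Nc4cc(C(F)(F)F)cc(C(F)(F)F)c4)c3)cc2-c2ccncc2)c1` is not yet measured. It differs from compound 1 in one place: trifluoromethyl in place of hydrogen on an aromatic carbon. The new group sits on an aromatic carbon of a six-membered aromatic ring of carbon only, meta to a trifluoromethyl group.

Going by the values given here, the only measured step that adds a group to this ring, a number 52.9 percentage points lower from compound 1 to compound 2 (beyond the scatter), lowered the number strongly, so a drop beyond the scatter is the more likely outcome here too, though with a different group the size is uncertain. The change is therefore expected to amount to a number 24.6 percentage points lower from compound 1 to compound 4 (beyond the scatter). Compound 4 is estimated to give -20%, within a range from -60% to 12%.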

Compound 4, a percentage reported as activity, at one concentration (the size of the read-out at that concentration, not a potency): -58%
Estimate against measurement, compound 4: 38 percentage points above; measured number inside the range.
By their numbers in this assay, from the lowest: compounds 4 and 2 (each within the scatter of the next); then compounds 3 and 1 (each within the scatter of the next).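

In this assay, the step to the second trifluoromethyl, a number 62.6 percentage points lower from compound 1 to compound 4 (beyond the scatter), shows that the strong fall seen with chloro, a number 52.9 percentage points lower from compound 1 to compound 2 (beyond the scatter), is not tied to that one added group. Compound 3 goes against any rule that a second group on this ring is enough, with its step to 3,4-dichlorophenyl, a number 1.6 percentage points lower from compound 1 to compound 3 (within the scatter), staying small. Nothing measured here explains why the number falls with some of these changes and not with others.

On these data alone, whether a methyl, a nitrile or an amine in the same place would also lower the number remains open. As far as these compounds go, these values each come from one concentration, so how compound 4 ranks in potency against compound 1 also remains open.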